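Trifluoromethyl for fluoro on a second core

This account rests on a few compounds, and the source may have more. Where it says the series, first, only, none or still open, it means among the compounds named here.

Measured so far:
compound 1, `Fc1ccc(-c2ccc(-c3ccc(-c4nc5ccccc5[nH]4)cc3)cc2)cc1`, 35600 nM in a functional assay on DWD cells (Homo sapiens) for inhibition, read by sulforhodamine B assay; on this read-out lower numbers stand for stronger inhibition of growth and higher numbers for weaker inhibition of growth
compound 2, `FC(F)(F)c1ccc(-c2ccc(-c3ccc(-c4nc5ccccc5[nH]4)cc3)cc2)cc1`, 100000 nM
compound 3, `Cc1ccc2[nH]c(-c3ccc(-c4ccc(-c5ccc(F)cc5)cc4)cc3)nc2c1`, 33100 nM

The change of interest is trifluoromethyl in place of fluoro on an aromatic carbon, which gave a 2.8-fold higher number from compound 1 to compound 2 (0.45 log units; beyond the scatter). The same change is now applied on a second core: compound 4 is `Cc1ccc2[nH]c(-c3ccc(-c4ccc(-c5ccc(C(F)(F)F)cc5)cc4)cc3)nc2c1`, and its difference from compound 3 is trifluoromethyl in place of fluoro on an aromatic carbon. The two cores differ by methyl in place of hydrogen on an aromatic carbon, a change that gave a 1.1-fold lower number from compound 1 to compound 3 (0.03 log units; within the scatter), so compound 3 and compound 1 sit together on this read-out. With the place of the change identical on both cores, compound 4 is expected to follow the earlier step, a 2.7-fold higher number from compound 3 to compound 4 (0.43 log units; beyond the scatter), because the same change gave a 2.8-fold higher number from compound 1 to compound 2 (0.45 log units; beyond the scatter). Compound 4 is therefore estimated at 90000 nM, within 40000 nM to 200000 nM.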

Compound 4, concentration for 50% growth inhibition: 38200 nM
Compound 4: middle estimate off by 2.4-fold (0.37 log units), on the high side; the measured number lies below the stated range.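

Trifluoromethyl in place of fluoro on the methyl-bearing core gives a 1.2-fold higher number from compound 3 to compound 4 (0.06 log units; within the scatter) in this assay, so the step does not clearly recur there, yet the two steps cannot be told apart: the same change on two cores in this assay, a 2.8-fold higher number (0.45 log units; beyond the scatter) from compound 1 to compound 2 and a 1.2-fold higher number (0.06 log units; within the scatter) from compound 3 to compound 4, 2.4-fold (0.39 log units) apart, within the scatter of two such steps

Read the other way, methyl in place of hydrogen gives a 2.6-fold lower number from compound 2 to compound 4 (0.42 log units; beyond the scatter), and this step likewise cannot be told apart from its counterpart on the fluoro compounds: the same change on two cores in this assay, a 1.1-fold lower number (0.03 log units; within the scatter) from compound 1 to compound 3 and a 2.6-fold lower number (0.42 log units; beyond the scatter) from compound 2 to compound 4, 2.4-fold (0.39 log units) apart, within the scatter of two such steps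

The two cores therefore show neither that the change carries over unaltered nor that the core alters it, and one pair of cores cannot settle the question.

Going by these compounds, it remains open how an amine, a carboxylic acid or a nitrile in that place would behave on either core. On these data alone, whether methyl on the core matters with such groups is also open.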